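A few compounds are considered here, and "the series" means these few. Any claim that something is new, unique, unknown or untested is made for them only; others in the source may bear on it.

Measured compounds and values in an assay on CHO cells for displacement of a labelled ligand from adenosine receptor A3 (Homo sapiens), read by scintillation counting, with a stated time of 3 h; on this read-out lower numbers stand for stronger inhibition and higher numbers for weaker inhibition:
- compound 1 `Cn1c(-c2ccccc2)nc2c(NC3CCCC3)ncnc21`: 846 nM
- compound 2 `CCn1c(-c2ccccc2)nc2c(NC3CCCCC3)ncnc21`: 707 nM
- compound 3 `Cn1c(-c2ccc(C(=O)O)cc2)nc2c(NC3CCCC3)ncnc21`: 25700 nM

Compound 1 sits second highest of the three numbers; compound 2 lies within the scatter of it, whereas compound 3 is far higher, the step being a 30-fold higher number from compound 1 to compound 3 (1.48 log units; beyond the scatter).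

Compound 4 `Cc1ccccc1-c1nc2c(NC3CCCC3)ncnc2n1C` differs from compound 1 by methyl in place of hydrogen on an aromatic carbon. Going by the values given here, no measured step covers a methyl on this aromatic carbon; the only step at this ring, from compound 1 to compound 3, concerns a carboxy and was large. Methyl and carboxy are unlike, so that step gives no direct guide. In this assay a step no larger than the scatter is expected for compound 4, estimated at a 1.2-fold higher number from compound 1 to compound 4 (0.07 log units; within the scatter).

Compound 4 is expected at 1000 nM, range 300 nM to 3500 nM.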

Compound 4, inhibition constant: 3000 nM
For compound 4 the middle estimate is 3.0-fold (0.48 log units) below the measured one, within the range that was stated.
By their numbers in this assay, from the lowest: compounds 2 and 1 (each within the scatter of the next); then compound 4; then compound 3.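

Phenyl to 2-methylphenyl gives a 3.5-fold higher number from compound 1 to compound 4 (0.55 log units; beyond the scatter) in this assay, so a single methyl ortho to a large group is enough to leave the scatter. Until now the only step at this ring was the carboxy one, a 30-fold higher number from compound 1 to compound 3 (1.48 log units; beyond the scatter), and both substitutions shown on the ring raise the number, with no compound shown going against this. No supporting data bear on why the methyl has this effect. Still open, from the compounds shown here alone, is whether the rise belongs to the methyl itself or to its place on the ring. A chlorine, a methoxy or an amine at this carbon would help to separate the two.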